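Urea-terminus variation in this series: notes toward compound 4

The source may hold more compounds than are shown below. What is called first, only, known or untested is meant among the compounds shown, and "the series" means these compounds.

Three measured compounds share one core and differ only at the terminus of the urea. In a functional assay on HEK293 cells for agonist activity at Vasopressin V2 receptor (Homo sapiens), read by a luciferase reporter and cAMP accumulation (a higher number here means that more compound is needed for the effect, a lower number that less compound is needed), compound 1 `Cc1cc(C(=O)N2CCCCc3ccccc32)ccc1CNC(=O)NCC(N)=O` gives 210 nM, compound 2 `Cc1cc(C(=O)N2CCCCc3ccccc32)ccc1CNC(=O)NCC(=O)N1CCCCC1` gives 150 nM, and compound 3 `CCN(CC)C(=O)[C@@H]1CCCN1C(=O)NCc1ccc(C(=O)N2CCCCc3ccccc32)cc1C` gives 350 nM. Compound 3 stands highest of the three numbers; its nearest neighbour is shown by a 1.7-fold higher number from compound 1 to compound 3 (0.22 log units; within the scatter) and its furthest by a 2.3-fold higher number from compound 2 to compound 3 (0.37 log units; beyond the scatter). The remaining pair is described by a 1.4-fold lower number from compound 1 to compound 2 (0.15 log units; within the scatter).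

Compound 4 `Cc1cc(C(=O)N2CCCCc3ccccc32)ccc1CNC(=O)N1CC(=O)C[C@H]1C(=O)N(C)C` differs from compound 3 by 2-(dimethylcarbamoyl)-4-oxopyrrolidin-1-yl in place of 2-(diethylcarbamoyl)pyrrolidin-1-yl on a carbonyl carbon. Within the data shown here, the steps that bear on this change are the two that alter the same carbonyl carbon, a 1.7-fold higher number from compound 1 to compound 3 (0.22 log units; within the scatter) and a 2.3-fold higher number from compound 2 to compound 3 (0.37 log units; beyond the scatter), one within the scatter and one modest. Since a 1.7-fold higher number from compound 1 to compound 3 (0.22 log units; within the scatter) and a 2.3-fold higher number from compound 2 to compound 3 (0.37 log units; beyond the scatter) are both small, the step of a 1.1-fold higher number from compound 3 to compound 4 (0.06 log units; within the scatter) is expected to be small as well, with no clear direction beyond the scatter in this assay. Compound 4 is therefore estimated at 400 nM, within a range of 150 nM to 1100 nM.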

Compound 4, half-maximal effective concentration: 27 nM
Compound 4: middle estimate off by 15-fold (1.17 log units), on the high side; the measured number lies below the stated range.
By their numbers in this assay, from the lowest: compound 4; then compounds 2, 1 and 3 (each within the scatter of the next, the first and the last beyond it).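

Within this assay, the earlier steps at this carbonyl carbon were small, whereas 2-(dimethylcarbamoyl)-4-oxopyrrolidin-1-yl in place of 2-(diethylcarbamoyl)pyrrolidin-1-yl gives the largest step in the series (a 13-fold lower number from compound 3 to compound 4 (1.11 log units; beyond the scatter)). The same group also separates compound 4 from the two compounds with acyclic termini (a 5.6-fold lower number from compound 2 to compound 4 (0.74 log units; beyond the scatter); a 7.8-fold lower number from compound 1 to compound 4 (0.89 log units; beyond the scatter)), so compound 4 has the lowest number of the four, with all its steps beyond the scatter. No supporting data on the origin of this step are available.

The step combines two changes, the 4-oxo group and dimethyl in place of diethyl on the carbamoyl nitrogen, and the compounds shown do not separate them. As far as these compounds go, whether a hydroxyl group in place of the 4-oxo group would keep the low number remains open.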